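Swapping Thiophen-3-yl for 2-Methoxyphenyl in Compound 4

The source may hold more compounds than are shown below. What is called first, only, known or untested is meant among the compounds shown, and "the series" means these compounds.

Measured compounds:
compound 1, `Brc1cn2ccnc2c(-c2ccc3ncn(C4CCCCC4)c3c2)n1`: 18%
compound 2, `Fc1ccc(-c2cn3ccnc3c(-c3ccc4ncn(C5CCCCC5)c4c3)n2)cc1`: 24.7%
compound 3, `c1cn2cc(-c3ccsc3)nc(-c3ccc4ncn(C5CCCCC5)c4c3)c2n1`: 22%

These three numbers come from a functional assay on K562 cells (Homo sapiens) for inhibition, read by sulforhodamine B assay, with a stated time of 48 h, tested at 10 uM; on this read-out higher numbers stand for more inhibition at the one concentration tested (going by the name of the read-out) and lower numbers for less inhibition. Compound 3 stands second highest of the three; its nearest neighbour is compound 2, with a number 2.7 percentage points lower from compound 2 to compound 3 (within the scatter), and its furthest is compound 1, with a number 4 percentage points higher from compound 1 to compound 3 (within the scatter). Since both steps lie within the scatter, no ordering among the three can be claimed.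

Compound 4, `COc1ccccc1-c1cn2ccnc2c(-c2ccc3ncn(C4CCCCC4)c3c2)n1`, is yet to be measured. It differs from compound 3 in one place: 2-methoxyphenyl in place of thiophen-3-yl on an aromatic carbon. For the measured compounds named here, the steps that bear on this change are those that alter the same position: a number 6.7 percentage points higher from compound 1 to compound 2 (within the scatter), a number 4 percentage points higher from compound 1 to compound 3 (within the scatter) and a number 2.7 percentage points lower from compound 2 to compound 3 (within the scatter), all within the scatter. Replacing one aromatic group by another at this position has so far produced no step beyond the scatter, so the expected step is a number 1 percentage points higher from compound 3 to compound 4 (within the scatter), essentially none. Compound 4 is therefore estimated at 23%, within a range of 12% to 34% in this assay.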

Compound 4, a percentage reported as inhibition, at one concentration (the size of the read-out at that concentration, not a potency): 22.6%
Beside the measured number, compound 4's estimate is 0.4 percentage points above it; the measured number falls inside the stated range.
By their numbers in this assay, from the lowest: compounds 1, 3, 4 and 2 (each within the scatter of the next).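

In this assay, the step to the larger 2-methoxyphenyl group, with 8 heavy atoms against the 5 of thiophen-3-yl, stays small (a number 0.6 percentage points higher from compound 3 to compound 4 (within the scatter)). The steps from the two other compounds are no larger in kind (a number 2.1 percentage points lower from compound 2 to compound 4 (within the scatter); a number 4.6 percentage points higher from compound 1 to compound 4 (within the scatter)). A methoxy-bearing ring thus joins bromo, 4-fluorophenyl and thiophen-3-yl on this aromatic carbon, and all six steps among these four groups lie within the scatter, so the position still shows no ordering among them.

As far as these compounds go, whether an amine or a carboxylic acid on this carbon would give a step beyond the scatter remains open, as does what a change elsewhere on the shared core would do. Nothing measured here accounts for how little these four compounds differ.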